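Adding a methyl to the pyridine of compound 2

This account rests on a few compounds, and the source may have more. Where it says the series, first, only, none or still open, it means among the compounds named here.

Compound 1 (`Cn1c(COc2cccc(C(=O)O)c2)nc2ccc(Oc3ccc(F)cc3)nc21`) gives 1.5 in a physicochemical assay for lipophilicity, read by LC-MS, in phosphate buffer, measured as octanol-water partition, with a stated time of 30 min, at pH 7.4, tested at 200 mM; a higher number here means a more lipophilic compound, a lower number a more polar compound
Compound 2 (`Cn1c(COc2cccc(C(=O)O)c2)nc2ccc(Oc3ccccn3)cc21`) gives 0.4 in this assay

Of these two compounds, compound 2 stands lower at 0.4, with compound 1 at 1.5 on this scale. The gap between the two lies beyond the scatter. Compound 3 (`Cc1cccc(Oc2ccc3nc(COc4cccc(C(=O)O)c4)n(C)c3c2)n1`) departs from compound 2 in one place: methyl in place of hydrogen on an aromatic carbon with methyl in place of hydrogen on an aromatic carbon, next to the ring nitrogen, so that pyridin-2-yl becomes 6-methylpyridin-2-yl. Going by the values given here, no measured pair shows this change, so the expectation rests on the structural change alone. In this assay a modest rise beyond the scatter is expected, with an estimated a number 0.50 log units higher from compound 2 to compound 3 (beyond the scatter) as the step. Compound 3 is estimated at 0.9 with an expected range from 0.5 to 1.3 in this measurement.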

Compound 3, distribution coefficient: 0.8
Estimate against measurement, compound 3: 0.10 log units above; the measured number falls inside the stated range.
By their numbers in this assay, from the lowest: compound 2; then compound 3; then compound 1.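

Methyl in place of hydrogen on an aromatic carbon, next to the ring nitrogen, gives in this assay a number 0.40 log units higher from compound 2 to compound 3 (beyond the scatter), the first step read at this position. Going by these compounds alone, compound 1 differs from compound 2 in more than one place, so it offers no step for comparison. Nothing on hand accounts for the size of this step.

From the compounds shown here alone, whether an ethyl group, a methoxy group or an amine on the same carbon would give a step of similar size stays open. So does the size of the step for methyl on another carbon of that ring.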